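The compounds below may be only part of what the source reports. "The series", "measured", "known", "first", "only" and "open" are said of these compounds alone.

Working notes on the series. In a functional assay on L1210 cells (Mus musculus) for inhibition, read by MTT assay, with a stated time of 72 h (on this read-out higher numbers stand for weaker inhibition and lower numbers for stronger inhibition), compound 2 `COc1cc(NC(C)CCCNC(=O)NNC(=O)Nc2ccc(Cl)cc2)c2ncccc2c1` gives the highest number of the three measured, 58000 nM; compound 1 `COc1cc(NC(C)CCCNC(=O)Nc2ccc(Br)cc2)c2ncccc2c1` gives 18000 nM and compound 3 `COc1cc(NC(C)CCCNC(=O)Nc2ccc(Cl)cc2)c2ncccc2c1` gives 19000 nM, so that a 3.2-fold higher number from compound 1 to compound 2 (0.51 log units; beyond the scatter) and a 3.1-fold lower number from compound 2 to compound 3 (0.48 log units; beyond the scatter), whereas a 1.1-fold higher number from compound 1 to compound 3 (0.02 log units; within the scatter). Compound 4 `COc1cc(NC(C)CCCNC(=O)NNC(=O)Nc2cccc(Cl)c2)c2ncccc2c1` is still to be measured; relative to compound 2 the change is 3-chlorophenyl in place of 4-chlorophenyl on an amide-type nitrogen. For the measured compounds named here, no measured step shifts the chloro to another place on that ring. Going by the values given here, the only step touching the ring, a 1.1-fold higher number from compound 1 to compound 3 (0.02 log units; within the scatter), stays within the scatter, and the other two steps concern a different part of the molecule, so they offer no guide to this change. For compound 4 in this assay, therefore, no step beyond the scatter is expected, a 1.2-fold lower number from compound 2 to compound 4 (0.06 log units; within the scatter). The estimate for compound 4 is 50000 nM, with a range from 18000 nM to 150000 nM.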

Compound 4, half-maximal inhibitory concentration: 27000 nM
The estimate for compound 4 lay 1.9-fold (0.27 log units) above the measured number; the range from low to high includes it.
By their numbers in this assay, from the lowest: compounds 1, 3 and 4 (each within the scatter of the next); then compound 2.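

In this assay, for the compounds shown here, the place of the chloro on the ring matters here: 3-chlorophenyl in place of 4-chlorophenyl on the amide-type nitrogen is the first ring change beyond the scatter (a 2.1-fold lower number from compound 2 to compound 4 (0.33 log units; beyond the scatter)). With the chloro in this place, the ((3-chlorophenyl)carbamoyl)amino chain stays within the scatter of the shorter compounds (a 1.4-fold higher number from compound 3 to compound 4 (0.15 log units; within the scatter); a 1.5-fold higher number from compound 1 to compound 4 (0.18 log units; within the scatter)). The gap that separated compound 2 from compound 3 therefore does not appear for compound 4.

Open, from the compounds shown here alone, is whether 3-bromophenyl, or a methoxy or an amino group in place of the chloro, would behave alike. No evidence at hand bears on the reason for this shift.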